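The source may report more compounds than this note shows. Statements on the series, on what has been measured and on what is new or still open speak of the compounds shown alone.

Compound 1 `COc1cc(-c2nn(-c3ccc(NC(=O)c4ccc(Cl)c(Cl)c4)cc3)cc2-c2ccncc2)ccc1Cl` and compound 2 `COc1cc(-c2nn(-c3ccc(NC(=O)c4cc(Cl)cc(Cl)c4)cc3)cc2-c2ccncc2)ccc1Cl` share one core, compound 2 carrying (3,5-dichlorophenyl in place of 3,4-dichlorophenyl on a carbonyl carbon). In a functional assay on UACC-257 cells (Homo sapiens) for antiproliferative activity, read by sulforhodamine B assay, with a stated time of 48 h (on this read-out lower numbers stand for stronger inhibition and higher numbers for weaker inhibition), compound 1 reaches only the limit > 100000 nM. In this assay compound 2 likewise stops at the limit > 100000 nM. Thus a step that the two limits leave unreadable from compound 1 to compound 2, both values resting at the limit of > 100000 nM in this assay, at which 2 of the 3 values shown sit. Compound 3 `O=C(Nc1ccc(-n2cc(-c3ccncc3)c(-c3ccc(Cl)c(O)c3)n2)cc1)c1ccc(Cl)c(Cl)c1` differs from compound 1 by hydrogen in place of methyl on an oxygen on an aromatic ring; in this assay compound 3 gives 4740 nM, so an at least 21-fold lower number from compound 1 to compound 3 (1.32 log units; beyond the scatter). Compound 4 `O=C(Nc1ccc(-n2cc(-c3ccncc3)c(-c3ccc(Cl)c(O)c3)n2)cc1)c1cc(Cl)cc(Cl)c1` is not yet measured and stands to compound 3 as compound 2 stands to compound 1, differing by 3,5-dichlorophenyl in place of 3,4-dichlorophenyl on a carbonyl carbon, the same change at the same place. For compound 4 a step of a 1.7-fold higher number from compound 3 to compound 4 (0.23 log units; within the scatter) is expected beside the earlier, unreadable one, the expectation resting on compound 3 keeping its hydroxy and on the size of an at least 21-fold lower number from compound 1 to compound 3 (1.32 log units; beyond the scatter). Compound 4 is estimated at 8000 nM, within 2500 nM to 40000 nM.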

Compound 4, half-maximal inhibitory concentration: 5700 nM
The estimate for compound 4 lay 1.4-fold (0.15 log units) above the measured number; measured number inside the range.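

In this assay, 3,5-dichlorophenyl in place of 3,4-dichlorophenyl on the core of compound 3 gives a 1.2-fold higher number from compound 3 to compound 4 (0.08 log units; within the scatter), so on this core the change leaves no readable mark. On these data alone, the same change on the core of compound 1 cannot be read, so whether it carries from one core to the other stays untested: the limit of > 100000 nM in this assay, at which 2 of the 4 values shown sit. Hydrogen in place of methyl on the oxygen gives an at least 17-fold lower number from compound 2 to compound 4 (1.24 log units; beyond the scatter), so that change lowers the number with either dichlorophenyl group, though how closely the sizes agree is not shown: the same change on two cores in this assay, an at least 21-fold lower number (1.32 log units; beyond the scatter) from compound 1 to compound 3 and an at least 17-fold lower number (1.24 log units; beyond the scatter) from compound 2 to compound 4; the limit leaves it open whether they differ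

Still open, as far as these compounds go, is how a longer chain or a carboxylic acid on that oxygen would read in this assay. Also open, from the compounds shown here alone, is how an amine in place of one chlorine on the dichlorophenyl group would read.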